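A few compounds are considered here, and "the series" means these few. Any claim that something is new, unique, unknown or untested is made for them only; others in the source may bear on it.

A compound that dissolves poorly is hard to test reliably, so solubility is worth checking for every new structure. In a physicochemical assay for solubility, at pH 7.4 (a lower number here means a less soluble compound, a higher number a more soluble compound), compound 1 `CCCCCCCc1cn(-c2ccc(CNC(=O)[C@H]3NCC[C@@H]3O)cc2)nn1` gives 3.1 ug/mL and compound 3 `CCCCCCCc1nnc(-c2ccc(CNC(=O)[C@H]3NCC[C@@H]3O)cc2)o1` gives 2.1 ug/mL, two values within the usual scatter of each other. Compound 2 `CCCCCCc1nc(-c2ccc(CNC(=O)[C@H]3NCC[C@@H]3O)cc2)no1` gives > 50 ug/mL, which is a limit of the assay and not a number. It is the only one of the three measured compounds to reach that limit, so its true position is not known exactly.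

Compound 4 `CCCCCc1nc(-c2ccc(CNC(=O)[C@H]3NCC[C@@H]3O)cc2)no1` differs from compound 2 in a single place: hydrogen in place of methyl on a saturated chain carbon, five bonds along the chain from an aromatic carbon. In words, this is hydrogen in place of methyl on a saturated chain carbon, five bonds along the chain from an aromatic carbon. Within the data shown here, no measured pair here shows this change on its own, so the expectation rests on the small size of the change and on the high starting point of compound 2. A slight rise in this assay is expected, but no step beyond the scatter. The expected size of the step is a step that the limit leaves unreadable from compound 2 to compound 4. Compound 4 may well be reported only as a limit again. As a number, compound 4 is estimated at 70 ug/mL, with an expected range from 30 ug/mL to 200 ug/mL.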

Compound 4, solubility: > 50 ug/mL
Compound 4: only a limit was reported (the forecaster's own chance of this, stated with the estimate: 75%); the middle value is on the limit's open side.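

Compound 4 gives > 50 ug/mL as a limit of the assay and not a number. No step can be read between compound 2 and compound 4, because neither has an exact value: the limit of > 50 ug/mL in this assay, at which 2 of the 4 values shown sit. The compounds shown leave open how soluble these two really are, and whether hydrogen in place of methyl changes that at all.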